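Pyridine Hydroxamic Acids Against HDAC6: An Amino Substituent

This account rests on a few compounds, and the source may have more. Where it says the series, first, only, none or still open, it means among the compounds named here.

Measured compounds:
Compound 1 `Cc1ccc(C(=O)NO)cn1` gives 70 nM.
Compound 2 `O=C(NO)c1cccnc1` gives 679 nM.

For the measured compounds named here, in an assay on Sf9 cells for inhibition of protein deacetylase HDAC6 (Homo sapiens), read by fluorescence (on this read-out lower numbers stand for stronger inhibition and higher numbers for weaker inhibition), compound 2 stands as the highest of the two numbers measured; its nearest neighbour is compound 1, and the single step recorded between them, a 9.7-fold higher number from compound 1 to compound 2 (0.99 log units; beyond the scatter), is the only one available. Compound 3 `Nc1ccc(C(=O)NO)cn1` differs from compound 2 by amino in place of hydrogen on an aromatic carbon. Going by the values given here, this change sits at the same aromatic carbon that carries the methyl in compound 1, so the step from compound 1 to compound 2 is the one that bears on it; yet an amino group is not a methyl, and no step with an amino group has been measured. The expected direction is therefore a lower number for compound 3, of a size smaller than the methyl step, as a 3.1-fold lower number from compound 2 to compound 3 (0.49 log units; beyond the scatter). Compound 3 is accordingly estimated at 220 nM, within a range from 60 nM to 800 nM.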

Compound 3, half-maximal inhibitory concentration: 240 nM
Beside the measured number, compound 3's estimate is 1.1-fold (0.04 log units) below it, within the range that was stated.
By their numbers in this assay, from the lowest: compound 1; then compound 3; then compound 2.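

In this assay, for the compounds shown here, compound 3 shows that methyl is not the only group at this aromatic carbon, next to the ring nitrogen, that is tied to a lower number than hydrogen: the amino group gives a 2.8-fold lower number from compound 2 to compound 3 (0.45 log units; beyond the scatter) here. The two groups are not interchangeable at this carbon, as amino in place of methyl gives a 3.4-fold higher number from compound 1 to compound 3 (0.54 log units; beyond the scatter) and leaves compound 3 between the other two compounds. No measurement at hand accounts for either step or for the gap between the two groups.

As far as these compounds go, whether a dimethylamino group, a methoxy group, a fluorine atom or a carboxylic acid at this carbon would fall in the same stretch of numbers stays open. So does the outcome of a longer chain there, or of methyl or amino at another carbon of the ring.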